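Removing the Methoxy Group from Compound 1

This account rests on a few compounds, and the source may have more. Where it says the series, first, only, none or still open, it means among the compounds named here.

Compound 1 `COc1ccc(N2C(=O)COc3ccc(-c4cnc5ccccc5c4)cc32)cc1` pairs a shared cyclic amide core with a 4-methoxyphenyl group. In a functional assay on A549 cells (Homo sapiens) for antiproliferative activity, read by MTT assay, with a stated time of 72 h (a lower number here means a stronger inhibitor, a higher number a weaker inhibitor), compound 1 gives > 40000 nM, which is a limit of the assay and not a measured number. Compound 1 therefore stands at the limit of > 40000 nM in this assay, at which 1 of the 3 values shown sits, and is the only one of the three measured compounds to do so.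

Two further compounds share the core but carry a sulfonamide-bearing pyridine in place of the fused bicyclic aromatic group. Compound 2 `COc1ccc(N2C(=O)COc3ccc(-c4cnc(OC)c(NS(=O)(=O)c5ccc(F)cc5)c4)cc32)cc1` gives 1350 nM in this assay. Compound 3 `O=C1COc2ccc(-c3cnc(Cl)c(NS(=O)(=O)c4ccc(F)cc4)c3)cc2N1c1ccccc1` gives 14700 nM in this assay. Compound 2 and compound 3 differ from each other in more than one place, so their two values show only that the substituted pyridine series reaches measurable numbers while compound 1 does not.

Compound 4 `O=C1COc2ccc(-c3cnc4ccccc4c3)cc2N1c1ccccc1` differs from compound 1 by hydrogen in place of methoxy on an aromatic carbon. Among the measured compounds shown here, no measured pair isolates this change, so nothing in the numbers points to a shift in either direction. The step of a number no higher from compound 1 to compound 4 (the limit leaves the size open) is expected to stay within the scatter, because compound 1 already sits at the limit of > 40000 nM in this assay, at which 1 of the 3 values shown sits, and the change is small. Compound 4 is expected to give 40000 nM, with a range from 15000 nM to 100000 nM, and most likely again only a limit.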

Compound 4, half-maximal inhibitory concentration: > 40000 nM
Compound 4 gave a limit, no number; the forecaster's own chance of this, stated with the estimate: 80%; the middle value sits exactly at the limit.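

Compound 1 and compound 4 both stop at a limit of the assay and not at a number, so the step between them cannot be read: the limit of > 40000 nM in this assay, at which 2 of the 4 values shown sit.

The compounds shown leave open what hydrogen in place of methoxy does in this assay when the compound on either side of the change gives a measurable value.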